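The source may report more compounds than this note shows. Statements on the series, on what has been measured and on what is new or still open speak of the compounds shown alone.

Values measured in a functional assay on the whole organism for agonist activity, with Mus musculus as the target; a higher number here means that more compound is needed for the effect, a lower number that less compound is needed:

Compound 1 `O=C1CCCN1CC#CCn1cnc2ccccc21` gives > 100 mg/kg
Compound 2 `CC(C#CCN(C)C)N1CCCC1=O` gives 6.6 mg/kg
Compound 3 `CC(=O)N(C)CC#CCN1CCCC1` gives 0.55 mg/kg

The entry for compound 1 is a limit of the assay, not a number. Of the two true numbers, compound 3 has the lower, at 0.55 mg/kg. Compound 2 needs more, and that gap lies beyond the usual scatter. Compound 4 `COC(=O)N(C)CC#CCN1CCCC1` differs from compound 3 by methoxy in place of methyl on a carbonyl carbon, acetyl to methoxycarbonyl (methoxy in place of methyl on a carbonyl carbon). For the measured compounds named here, no measured pair shows this change, so the guide is weak. A modest rise in the dose needed in this assay is expected, an estimated step of a 2.7-fold higher number from compound 3 to compound 4 (0.44 log units; beyond the scatter). For compound 4 the estimated dose is 1.5 mg/kg, with an expected range of 0.3 mg/kg to 8 mg/kg.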

Compound 4, dose for half-maximal effect: 3 mg/kg
Compound 4: the middle estimate sits 2.0-fold (0.30 log units) below what was measured; low and high end bracket the measured number.
By their numbers in this assay, from the lowest: compound 3; then compound 4; then compound 2. At a limit, above all of these: compound 1.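

At this carbonyl carbon, whose other neighbour is an amide-type nitrogen, the group present matters: in this assay, putting methoxy in place of methyl gives a 5.5-fold higher number from compound 3 to compound 4 (0.74 log units; beyond the scatter). For the compounds shown here, this is the first comparison here between compounds that differ in only one place, and it shows that acetyl to methoxycarbonyl keeps a measurable effect but raises the dose needed. Nothing measured here bears on why the dose rises.

As far as these compounds go, what an ethyl group or an amine at this carbon would do remains open. So does whether this change would have the same effect on another core.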